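The source may report more compounds than this note shows. Statements on the series, on what has been measured and on what is new or still open speak of the compounds shown alone.

Measured compounds:
compound 1 `Cc1cc(OCCCCCCC[N+]23CCN(CC2)CC3)ccc1-n1cc(C(=O)Nc2cc(F)cc(F)c2)c(=O)c2ccc(N(C)C)nc21` — "not active" (no number reported)
compound 2 `CN(C)c1ccc2c(=O)c(C(=O)Nc3cc(F)cc(F)c3)cn(-c3ccc(OCCCCCCC[N+]45CCN(CC4)CC5)cc3F)c2n1` — 9.02%

In an assay on LX2 cells for inhibition of COL1A1 promoter (Homo sapiens), read by a luciferase reporter, with a stated time of 24 h, tested at 20 uM (on this read-out lower numbers stand for a weaker effect and higher numbers for a stronger effect at the one concentration tested), compound 1 gives "not active" (no number reported), reported without a number, so compound 1 stands without a single value here. Compound 2 gives 9.02% in this assay. For the measured compounds named here, no step between compound 1 and compound 2 is computed; their two values show only that each has at most a small effect at the one concentration tested.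

Compound 3 `CC[N+]1(CCCCCCCOc2ccc(-n3cc(C(=O)Nc4cc(F)cc(F)c4)c(=O)c4ccc(N(C)C)nc43)c(C)c2)CCCCC1` has not yet been measured in this assay. It differs from compound 1 by a group of 8 heavy atoms (7 carbon, 1 nitrogen; one six-membered non-aromatic ring with 1 hetero atom) in place of a group of 8 heavy atoms (6 carbon, 2 nitrogen; 2 six-membered non-aromatic rings with 2 hetero atoms each), on a saturated chain carbon, seven bonds along the chain from an oxygen on an aromatic ring. Going by the values given here, no measured pair tells what this exchange does, so its effect is open. Since compound 1 is reported as "not active" (no number reported), a step of no more than the usual scatter is expected in this assay, in no particular direction. Compound 3 is expected to give 8% in this assay, with a range from 0% to 25%.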

Compound 3, a percentage reported as inhibition, at one concentration (the size of the read-out at that concentration, not a potency): "not active" (no number reported)
No number was reported for compound 3, so the estimate cannot be set against anything.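

In this assay, for the compounds shown here, compound 1 and compound 3 both stand without a number, so no step between them can be read. The compounds shown leave open what exchanging the group on the chain does to this read-out. No measurement on hand bears on this result.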